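The source may report more compounds than this note shows. Statements on the series, on what has been measured and on what is new or still open speak of the compounds shown alone.

Measured in an in vitro ADME assay on microsomes from liver (Homo sapiens) for pharmacokinetics, read by LC-MS, with a stated time of 10 min, tested at 1 uM; a lower number here means slower removal, a higher number faster removal of the compound:
- compound 1 `CN1C[C@H](C(=O)Nc2ccccc2)[C@@H](c2ccc(/C=C/C(=O)Nc3ccccc3N)cc2)C1`: 7 mL/min/kg
- compound 2 `COc1cccc(NC(=O)[C@H]2CN(C)C[C@@H]2c2ccc(/C=C/C(=O)Nc3ccccc3N)cc2)c1`: 14 mL/min/kg
- compound 3 `Nc1ccccc1NC(=O)/C=C/c1ccc([C@H]2CN(C3COC3)C[C@@H]2C(=O)Nc2ccc(Cl)cc2)cc1`: 13 mL/min/kg

Compound 3, at 13 mL/min/kg, sits within the usual scatter of compound 2 at 14 mL/min/kg and also of compound 1 at 7 mL/min/kg. On these numbers, all three compounds cannot be told apart with confidence.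

The next compound to be tested is compound 4 `Nc1ccccc1NC(=O)/C=C/c1ccc([C@H]2CN(Cc3ccccc3)C[C@@H]2C(=O)Nc2ccc(Cl)cc2)cc1`. It keeps the rest of compound 3 and puts benzyl in place of oxetan-3-yl on an amine nitrogen in a ring.

Going by the values given here, only one single-change step has been measured, a 2.0-fold higher number from compound 1 to compound 2 (0.30 log units; within the scatter). That step swapped methoxy for hydrogen on an aromatic carbon, a different change in a different place, and it stayed within the scatter. Among the compounds with values here, no measured pair changes only the group on the amine nitrogen, so the data offer weak guidance here and the range must stay wide.

A modest move towards faster removal is expected in this assay, without clearly leaving the scatter. The expected step is a 1.5-fold higher number from compound 3 to compound 4 (0.19 log units; within the scatter). For compound 4 the estimated clearance is 20 mL/min/kg, with an expected range of 10 mL/min/kg to 40 mL/min/kg.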

Compound 4, clearance: 3 mL/min/kg
Compound 4: middle estimate off by 6.7-fold (0.82 log units), on the high side; measured number outside the range, below it.
By their numbers in this assay, from the lowest: compound 4; then compounds 1, 3 and 2 (each within the scatter of the next).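

Going by these compounds alone, the group on the amine nitrogen in the ring can clearly affect removal in this assay, since replacing oxetan-3-yl with benzyl gives a 4.3-fold lower number from compound 3 to compound 4 (0.64 log units; beyond the scatter) and this is the first single-change step here to lie beyond the scatter. The change swaps a four-membered non-aromatic ring with 4 heavy atoms and 1 hydrogen-bond acceptor for a group with 7 heavy atoms, a six-membered aromatic ring of carbon only and 0 hydrogen-bond acceptors, and in this one pair the larger group goes with slower removal. No measurement here explains why the step goes in this direction or why it has this size.

A single pair cannot separate the effect of the aromatic ring from that of the larger group, and cyclohexylmethyl, with a saturated ring in place of the aromatic one, or phenethyl, with a longer chain, would help to tell these apart. On these data alone, it also remains open whether benzyl gives a similar step when the (4-chlorophenyl)carbamoyl group is replaced, or whether a benzyl ring bearing a carboxylic acid or an amine would keep removal this slow.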